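This account rests on a few compounds, and the source may have more. Where it says the series, first, only, none or still open, it means among the compounds named here.

Compounds measured in a functional assay on MDA-MB-435 cells (Homo sapiens) for inhibition; on this read-out lower numbers stand for stronger inhibition of growth and higher numbers for weaker inhibition of growth:
compound 1, `COc1cc(/C=C/C(=O)c2cccc(-n3cc(-c4ccccc4)[nH]c3=O)c2)ccc1O`: 2140 nM
compound 2, `COc1ccc(-c2cn(-c3cccc(C(=O)/C=C/c4cc(OC)c(OC)c(OC)c4)c3)c(=O)[nH]2)cc1`: 1860 nM
compound 3, `COc1cc(/C=C/C(=O)c2cccc(-n3cc(-c4cc(OC)c(OC)c(OC)c4)[nH]c3=O)c2)cc(OC)c1OC`: 2110 nM

In this assay compound 1 gives the highest of the three numbers, yet its gaps to compound 3 and to compound 2 are both within the scatter, so the three compounds cannot be told apart on these values. Among the compounds with values here, the one structural step among them that is measured, a 1.1-fold higher number from compound 2 to compound 3 (0.05 log units; within the scatter), exchanges the aryl group on the shared core and changes the number by almost nothing.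

Compound 4, `COc1cc(/C=C/C(=O)c2cccc(-n3cc(-c4ccc(Cl)cc4)[nH]c3=O)c2)ccc1O`, differs from compound 1 by chloro in place of hydrogen on an aromatic carbon. This change sits on the same aryl group that is varied between compound 2 and compound 3, and that variation left the read-out unchanged. Within the data shown here, no other measured step bears on it. The account therefore expects no step beyond the scatter in this assay, in either direction, with the step of a 1.1-fold lower number from compound 1 to compound 4 (0.03 log units; within the scatter) as the expected outcome. Compound 4 is estimated at 2000 nM, in a range from 1000 nM to 4500 nM.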

Compound 4, concentration for 50% growth inhibition: 2250 nM
Compound 4: middle estimate off by 1.1-fold (0.05 log units), on the low side; the measured number falls inside the stated range.
By their numbers in this assay, from the lowest: compounds 2, 3, 1 and 4 (each within the scatter of the next).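

In this assay, chloro in place of hydrogen on the aromatic carbon para to a large group gives a 1.1-fold higher number from compound 1 to compound 4 (0.02 log units; within the scatter). Within the data shown here, the only earlier step, a 1.1-fold higher number from compound 2 to compound 3 (0.05 log units; within the scatter), exchanged one methoxy-bearing aryl group for another, whereas this step adds a single chlorine to an unsubstituted phenyl, and it too stays within the scatter. Nothing available explains why the number stays put at this position.

On these data alone, whether an amine, a carboxylic acid or a longer chain in place of the chloro would give a step beyond the scatter remains open. With both steps shown lying within the scatter, the compounds also leave open which part of the shared core, if any, governs growth inhibition in these cells.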